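Acetyl to dimethylamino on the pendant phenyl ring

This account rests on a few compounds, and the source may have more. Where it says the series, first, only, none or still open, it means among the compounds named here.

Measured so far:
compound 1 `COc1cc(C)cc(-c2c(-c3ccnc(-c4ccc(C(C)=O)cc4)c3)cnn2CC#N)c1`, 95%
compound 2 `COc1cc(C)cc(-c2nn(CC#N)cc2-c2ccc(-c3cccc(C(C)=O)c3)nc2)c1`, 84%
compound 3 `COc1cc(C)cc(-c2nn(CC#N)cc2-c2ccnc(-c3ccc(N(C)C)cc3)c2)c1`, 103%

All three share one core and are read in a functional assay on Hs-578T cells (Homo sapiens) for cytotoxicity, read by sulforhodamine B assay, with a stated time of 48 h, tested at 0.001 uM; a lower number here means a stronger effect, a higher number a weaker effect of the compound at the concentration tested. In this assay compound 1 gives 95%, the second highest of the three numbers. Compound 3 gives 103%, which lies within the scatter of compound 1. Compound 2 gives 84%, which lies beyond the scatter below compound 1. No pair among these three differs in only one place, so none of the gaps can be tied to a single change.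

The next compound, compound 4 `COc1cc(C)cc(-c2c(-c3ccnc(-c4ccc(N(C)C)cc4)c3)cnn2CC#N)c1`, differs from compound 1 in one place: dimethylamino in place of acetyl on an aromatic carbon. The only reference for a dimethylamino group in the series is compound 3, whose value in this assay sits within the scatter of compound 1, though compound 3 is not a single-change neighbour of either compound 1 or compound 4.

Within the data shown here, with no one-place step measured, a step of no size beyond the scatter is expected in this assay, in either direction, when compound 1 is turned into compound 4. The expected step is a number 4 percentage points higher from compound 1 to compound 4 (within the scatter). Compound 4 is therefore estimated at 99% in this assay, with a range from 86% to 112%.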

Compound 4, a percentage reported as activity, at one concentration (the size of the read-out at that concentration, not a potency): 88%
Estimate against measurement, compound 4: 11 percentage points above; low and high end bracket the measured number.
By their numbers in this assay, from the lowest: compounds 2, 4, 1 and 3 (each within the scatter of the next, the first and the last beyond it).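

In this assay, among these compounds, the one-place exchange of 4-acetylphenyl for 4-(dimethylamino)phenyl gives a number 7 percentage points lower from compound 1 to compound 4 (within the scatter) and is the first step that can be tied to a single change. On this aromatic carbon, para to a large group, acetyl and dimethylamino are therefore not told apart by this read-out, which gives the size of the effect at one concentration and not a potency. No measurement on hand bears on why the two groups read alike.

On these data alone, whether any group at this place moves the read-out beyond the usual scatter stays open, for example a primary amine, a carboxylic acid or a longer alkyl chain. Also open, as far as these compounds go, is whether acetyl and dimethylamino would still read alike at a higher concentration, where a single value at this low test level says nothing about how the two compounds behave.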